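Swapping a ring for a chain at the core nitrogen

This account rests on a few compounds, and the source may have more. Where it says the series, first, only, none or still open, it means among the compounds named here.

Two compounds carry the same fused core, with a substituent on one of its aromatic nitrogens. Compound 1 `CC(C)n1cnc2c(Nc3cccc(Cl)c3)nc(NCOCc3ccc(/C=C/C(=O)Nc4ccccc4N)cc3)nc21` and compound 2 `Nc1ccccc1NC(=O)c1ccc(COCNc2nc(Nc3ccccc3)c3ncn(C4CCCC4)c3n2)cc1` were both tested in a functional assay on NCI-H460 cells (Homo sapiens) for antiproliferative activity, read by CCK-8 assay, with a stated time of 72 h, tested at 2 uM; a lower number here means a weaker effect, a higher number a stronger effect of the compound at the concentration tested. Compound 1 reaches 53%. Compound 2 gives 41.2%, the lower of the two numbers, standing below compound 1 by a gap that is beyond the usual scatter.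

The next compound, compound 3 `CCCCn1cnc2c(Nc3ccccc3)nc(NCOCc3ccc(C(=O)Nc4ccccc4N)cc3)nc21`, keeps everything else of compound 2 and changes only the group on that aromatic nitrogen: butyl in place of cyclopentyl on an aromatic nitrogen. Within the data shown here, no measured pair shows what this exact exchange does, so the size of the step is open. With a group of similar bulk and no change in donors or acceptors, the expected step from compound 2 to compound 3 is a number 1.2 percentage points lower from compound 2 to compound 3 (within the scatter), that is, no clear shift beyond the scatter. Compound 3 is therefore estimated at 40%, within a range of 26% to 54%.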

Compound 3, a percentage reported as inhibition, at one concentration (the size of the read-out at that concentration, not a potency): 27.7%
Compound 3: middle estimate off by 12.3 percentage points, on the high side; the measured number falls inside the stated range.
By their numbers in this assay, from the lowest: compound 3; then compound 2; then compound 1.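

This position is not indifferent to its group: in this assay, butyl in place of cyclopentyl on an aromatic nitrogen gives a number 13.5 percentage points lower from compound 2 to compound 3 (beyond the scatter), although both groups are built of carbon only and carry no hydrogen-bond donors or acceptors. Among these compounds, this is the first direct reading at this position, as compound 1 and compound 2 differ in more than one place, and in this single pair the ring goes with the higher number. Nothing available says why the number falls.

On these data alone, whether the ring itself matters, or only the shape of the carbon group, stays open. A cyclohexyl ring, a longer chain such as hexyl, or a chain ending in an amine at this nitrogen could show how far this single step extends.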